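Triazole Analogues in B16 Cytotoxicity: An Estimate for Compound 4

A few compounds are considered here, and "the series" means these few. Any claim that something is new, unique, unknown or untested is made for them only; others in the source may bear on it.

Three compounds carry measurements in a functional assay on B16 cells (Mus musculus) for cytotoxicity, read by MTT assay, with a stated time of 48 h; a lower number here means a stronger inhibitor, a higher number a weaker inhibitor. Compound 2 `O=[N+]([O-])c1ccc(-c2cn(Cc3ccccc3)nn2)cc1` gives 5120 nM in this assay. Compound 1 `CC1(C)OC[C@H](Cn2cc(-c3ccc([N+](=O)[O-])cc3)nn2)O1` reaches only a limit of the assay in this assay, > 100000 nM, not a number. Compound 3 `Cc1ccc(C(O)c2cn(Cc3ccccc3)nn2)cc1` likewise reaches only a limit in this assay, > 100000 nM.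

The change from compound 2 to compound 1 is 2,2-dimethyl-1,3-dioxolan-4-yl in place of phenyl on a saturated chain carbon bound to an aromatic nitrogen; it produced an at least 19-fold higher number from compound 2 to compound 1 (1.29 log units; beyond the scatter). Two of the three measured values, those of compound 1 and compound 3, sit at the limit of > 100000 nM in this assay, at which 2 of the 3 values shown sit, so the assay has a ceiling that these compounds meet. The difference between the cores of compound 2 and compound 3 is not broken down here.

Compound 4 `Cc1ccc(C(O)c2cn(C[C@H]3COC(C)(C)O3)nn2)cc1` has not been measured. Within the data shown here, it differs from compound 3 by 2,2-dimethyl-1,3-dioxolan-4-yl in place of phenyl on a saturated chain carbon bound to an aromatic nitrogen, the same change as the one from compound 2 to compound 1, at the same place. Since compound 3 already stands at the limit of the assay, and the earlier step raised the number beyond the scatter, compound 4 is expected to stand at or beyond that limit as well. The step expected from compound 3 to compound 4 is estimated as a step that the limit leaves unreadable from compound 3 to compound 4. For compound 4 the expected value is 300000 nM, with a range of 100000 nM to 1000000 nM, and most likely only a limit will be reported.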

Compound 4, half-maximal inhibitory concentration: > 100000 nM
Compound 4: only a limit was reported; the forecaster's own chance of this, stated with the estimate: 90%; the middle value does not contradict the limit.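

In this assay compound 4 gives > 100000 nM, a limit of the assay and not a number. No step from compound 3 to compound 4 can be read, because compound 3 also stands at a limit: the limit of > 100000 nM in this assay, at which 3 of the 4 values shown sit.

The compounds shown leave open whether 2,2-dimethyl-1,3-dioxolan-4-yl in place of phenyl changes anything on the core of compound 3, as it did on the core of compound 2.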